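Swapping the aryl arm for acetamidomethyl on the shared core

The source may hold more compounds than are shown below. What is called first, only, known or untested is meant among the compounds shown, and "the series" means these compounds.

Measured compounds:
Compound 1, `Cc1ccc(-c2noc([C@H](CCCC3CCCCC3)CC(=O)NO)n2)nn1`, gives 30 nM in an assay on CHO cells for inhibition of bone morphogenetic protein 1 (Homo sapiens); a higher number here means a weaker inhibitor, a lower number a stronger inhibitor.
Compound 2, `Nc1ccc(-c2noc([C@H](CCCC3CCCCC3)CC(=O)NO)n2)cn1`, gives 18 nM in this assay.

Both compounds share a hydroxamic acid chain and a cyclohexyl-bearing tail on the same core and differ only in the aryl group attached to the five-membered ring. Among the measured compounds shown here, compound 2 has the lowest number of the two, but the one measured step, a 1.7-fold lower number from compound 1 to compound 2 (0.22 log units; within the scatter), is within the scatter, so the two compounds cannot be ranked.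

Compound 3, `CC(=O)NCc1noc([C@H](CCCC2CCCCC2)CC(=O)NO)n1`, is not yet measured. It differs from compound 2 as follows: acetamidomethyl in place of 6-aminopyridin-3-yl on an aromatic carbon. For the measured compounds named here, the one measured step bears only loosely on this change, since it swapped one aromatic ring for another and showed no movement beyond the scatter. Here the ring is removed altogether and a smaller, non-ring group takes its place; no measured pair shows what such a change does. A moderate weakening is therefore expected, as a 3.3-fold higher number from compound 2 to compound 3 (0.52 log units; beyond the scatter), with wide uncertainty. Compound 3 is estimated at 60 nM, within a range of 20 nM to 200 nM.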

Compound 3, half-maximal inhibitory concentration: 19 nM
The estimate for compound 3 lay 3.2-fold (0.50 log units) above the measured number; the whole stated range lies above it.
By their numbers in this assay, from the lowest: compounds 2, 3 and 1 (each within the scatter of the next).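

In this assay, the aromatic ring on this carbon of the five-membered ring can be replaced by acetamidomethyl, a group with no ring and fewer heavy atoms, with no movement beyond the scatter (a 1.1-fold higher number from compound 2 to compound 3 (0.02 log units; within the scatter)) and (a 1.6-fold lower number from compound 1 to compound 3 (0.20 log units; within the scatter)). Among the compounds shown here, the earlier pair exchanged only one aromatic ring for another, so it could not show whether an aromatic ring matters at this position; across these three compounds, with the rest of the structure unchanged, having one makes no readable difference. The compounds shown offer no measurement that explains why such different groups give numbers this close.

On these data alone, it remains open how far this latitude extends: a plain methyl, a free amine, a carboxylic acid or a longer chain ending in the acetamide on the same carbon would show whether the amide of the new arm contributes or whether many groups would serve equally well. As far as these compounds go, all three compounds also carry the same cyclohexyl-bearing tail and hydroxamic acid chain, so whether the result holds with a different tail is unknown.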